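This account rests on a few compounds, and the source may have more. Where it says the series, first, only, none or still open, it means among the compounds named here.

Measured compounds:
compound 1 `O/N=C(\CCN1CCN(c2ccccn2)CC1)c1ccccc1`: 70%
compound 2 `O/N=C(/CCN1CCN(c2ccccn2)CC1)c1ccccc1`: 74%

Going by the values given here, in a functional assay on HEK293 cells with D(4) dopamine receptor (Homo sapiens) as the target, read by FLIPR (a higher number here means a larger maximal response, a lower number a smaller maximal response), compound 1 gives 70%, and the only other number comes from compound 2, which gives 74%. The step between them, a number 4 percentage points higher from compound 1 to compound 2 (within the scatter), is within the scatter, and the two compounds share all atoms and bonds (the fact that compounds 1 and 2 differ only in the configuration as drawn).

Compound 3 `O/N=C(\CCN1CCN(c2ccccn2)CC1)c1ccccc1Cl` differs from compound 1 by chloro in place of hydrogen on an aromatic carbon. Among the compounds with values here, no measured step changes a chloro or any other group on this ring, so the one step known, a number 4 percentage points higher from compound 1 to compound 2 (within the scatter), does not bear on the change to compound 3. Without a measured precedent, the expectation for compound 3 is a number close to that of compound 1, with the step of a number 2 percentage points lower from compound 1 to compound 3 (within the scatter) expected to stay within the scatter in either direction. The estimate for compound 3 in this assay is 68%, expected to fall between 45% and 90%.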

Compound 3, largest response reached (reported as efficacy), in percent of the reference or control that the assay uses: 74%
For compound 3 the middle estimate is 6 percentage points below the measured one; the range from low to high includes it.
By their numbers in this assay, from the lowest: compounds 1, 2 and 3 (each within the scatter of the next).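

In this assay, chloro in place of hydrogen on an aromatic carbon, ortho to a large group, gives a step that lies within the scatter (a number 4 percentage points higher from compound 1 to compound 3 (within the scatter)), so this one comparison shows that this position can carry a chlorine with no readable difference in maximal response. Compounds 1 and 2 could not show this, as they carry the same atoms and bonds and say nothing about any group on this ring. Nothing shown here offers a cause for the chloro step.

The compounds shown leave open whether a methoxy group, an amine or a carboxylic acid at this place would also stay within the scatter of compound 1, and whether chloro would do so elsewhere on the ring. They also leave open what chloro does when the double bond is drawn Z, as in compound 2.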